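A few compounds are considered here, and "the series" means these few. Any claim that something is new, unique, unknown or untested is made for them only; others in the source may bear on it.

Measured so far in an ADME assay on microsomes from liver (Homo sapiens) for metabolic stability, read by LC-MS, using NADPH, with a stated time of 10 min, tested at 10 uM; a higher number here means that the compound lasts longer, a lower number that the compound disappears faster:
- compound 1 `N#Cc1ccnc(Oc2nn(C3CCC3)c3ncnc(N)c23)c1`: 2.35 h
- compound 2 `N#Cc1ccnc(Oc2nn([C@H]3C[C@H](O)C3)c3ncnc(N)c23)c1`: > 2.41 h (a limit, not a number)

Among the compounds with values here, compound 1, at 2.35 h, holds the only true number so far. The other result is the limit of > 2.41 h in this assay, at which 1 of the 2 values shown sits, and it belongs to compound 2.

Compound 3 `Nc1ncnc2c1c(Oc1cc(Cl)ccn1)nn2C1CCC1` has not yet been measured. It is compound 1 with chloro in place of cyano on an aromatic carbon.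

Within the data shown here, only one measured step exists, an at least 1.0-fold higher number from compound 1 to compound 2 (0.01 log units; that floor lies within the scatter). It swaps hydroxy for hydrogen on a saturated ring carbon, so it lies elsewhere in the molecule and does not touch the aromatic carbon that changes in compound 3. Its floor also lies within the scatter, so it gives no guide to size or direction. Among the measured compounds shown here, with no measured precedent for this swap, no step beyond the scatter is expected in this assay, and the middle estimate sits only slightly lower. The expected change is a 1.3-fold lower number from compound 1 to compound 3 (0.12 log units; within the scatter).

The estimated half-life of compound 3 is 1.8 h, with an expected range from 0.8 h to 3 h.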

Compound 3, half-life: 0.333 h
Compound 3: middle estimate off by 5.4-fold (0.73 log units), on the high side; the whole stated range lies above it.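

Chloro in place of cyano on this aromatic carbon, opposite the ring nitrogen, gives a 7.1-fold lower number from compound 1 to compound 3 (0.85 log units; beyond the scatter) in this assay, so the group at this position has a clear bearing on how long the compound lasts. The earlier step changed a saturated ring carbon elsewhere in the molecule, and its floor lay within the scatter. Within the data shown here, this is the first step here that lies beyond the scatter, and it is the first evidence on this aromatic position. The swap removes a triple bond and a hydrogen-bond acceptor and brings in a chlorine atom, but nothing shown here tells which of these differences accounts for the shorter half-life.

With only cyano and chloro shown at this position, it remains open whether the half-life would follow a pattern across other groups there, such as fluoro, methyl, methoxy or an amine. As far as these compounds go, it is also open how chloro at this position would behave alongside the hydroxy group on the saturated ring of compound 2.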